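This account rests on a few compounds, and the source may have more. Where it says the series, first, only, none or still open, it means among the compounds named here.

Working notes on the series. In a functional assay on SW480 cells (Homo sapiens) for antiproliferative activity, read by MTT assay, with a stated time of 48 h (on this read-out lower numbers stand for stronger inhibition and higher numbers for weaker inhibition), compound 1 `CCCCCCCCCCC(CCO)n1cnc2c(Cl)ncnc21` gives 3160 nM on the shared core, compound 2 `CCCCCCCCCCC(CCO)n1cnc2c(OC)ncnc21` gives 8260 nM and compound 3 `CCCCCCCCCCC(CCO)n1cnc2c(NC)ncnc21` gives 12000 nM in the same read-out. Two steps fix the standing of the methylamino member: a 1.5-fold higher number from compound 2 to compound 3 (0.16 log units; within the scatter) leaves it level with the methoxy member, and a 3.8-fold higher number from compound 1 to compound 3 (0.58 log units; beyond the scatter) puts it clearly apart from the chloro member.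

The next change leads to compound 4 `CCCCCCCCCCC(CCO)n1cnc2c(N)ncnc21` and reads hydrogen in place of methyl on a nitrogen on an aromatic ring in the form of hydrogen in place of methyl on a nitrogen on an aromatic ring, or methylamino to amino. Among the compounds with values here, no measured step makes this exact change. Within the data shown here, the steps that bear on it are swaps on an aromatic carbon. Leaving chloro gave modest steps, with a 2.6-fold higher number from compound 1 to compound 2 (0.42 log units; beyond the scatter) as the second case, while the exchange of methoxy for methylamino stayed within the scatter. Compound 4 keeps the nitrogen of compound 3 and differs only in the methyl, so no large step is expected in this assay. The anchor in these notes is compound 3 at 12000 nM. The estimate amounts to a 1.2-fold lower number from compound 3 to compound 4 (0.08 log units; within the scatter) and is expected to stay within the scatter. Compound 4 is expected at 10000 nM with an estimated range between 4500 nM and 22000 nM as the likely span.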

Compound 4, half-maximal inhibitory concentration: 1200 nM
Compound 4: middle estimate off by 8.3-fold (0.92 log units), on the high side, outside the stated range (below it).
By their numbers in this assay, from the lowest: compound 4; then compound 1; then compounds 2 and 3 (each within the scatter of the next).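

In this assay the methyl on this nitrogen matters far more than the earlier swaps suggested: hydrogen in its place gives a 10-fold lower number from compound 3 to compound 4 (1.00 log units; beyond the scatter) and this exceeds every step among compound 1, compound 2 and compound 3. The amino member also stands apart from the other two groups at this position, with a 6.9-fold lower number from compound 2 to compound 4 (0.84 log units; beyond the scatter) and a 2.6-fold lower number from compound 1 to compound 4 (0.42 log units; beyond the scatter) as the steps, so chloro no longer gives the lowest number and compound 4 ranks first of the four in this read-out. Nothing on hand accounts for so large a gap between methylamino and amino.

The compounds shown leave open whether a larger group at this position, such as ethylamino or dimethylamino, stays level with compound 3. They also leave open whether the standing of amino holds with a shorter alkyl chain on the shared core, or with a carboxylic acid in place of the terminal hydroxyl.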